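The compounds below may be only part of what the source reports. "The series", "measured", "known", "first", "only" and "open" are said of these compounds alone.

Working notes on the series. Compound 1 `N#CCCn1nc(-c2ccc(OCc3ccc(Cl)cc3)cc2)oc1=S` is the reference on the first core; in an assay for inhibition of Amine oxidase [flavin-containing] B (Rattus norvegicus) (a lower number here means a stronger inhibitor, a higher number a weaker inhibitor), compound 1 gives 690 nM. Compound 2 `N#CCCn1nc(-c2ccc(OCc3ccc([N+](=O)[O-])cc3)cc2)oc1=S` carries nitro in place of chloro on an aromatic carbon; in this assay compound 2 gives 4300 nM, and the step reads a 6.2-fold higher number from compound 1 to compound 2 (0.79 log units; beyond the scatter). Compound 3 `N#CCCN1N=C(c2ccc(OCc3ccc(Cl)cc3)cc2)OCC1=O` stands on a second core; the difference between the two cores is not broken down here. In this assay compound 3 gives 100 nM, the lowest of the three numbers, with compound 1 nearest and compound 2 furthest from it. Compound 4 `N#CCCN1N=C(c2ccc(OCc3ccc([N+](=O)[O-])cc3)cc2)OCC1=O` is not yet measured and differs from compound 3 by nitro in place of chloro on an aromatic carbon. This is the same change as the one from compound 1 to compound 2, now on the core of compound 3; it occurs twice among the compounds shown, and only one instance is measured. For compound 4 a step of a 6.0-fold higher number from compound 3 to compound 4 (0.78 log units; beyond the scatter) is expected in this assay. Among the measured compounds shown here, the expectation rests on the single measured instance, a 6.2-fold higher number from compound 1 to compound 2 (0.79 log units; beyond the scatter), carried over unchanged to the second core. Compound 4 is estimated at 600 nM, with a range from 250 nM to 1500 nM.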

Compound 4, half-maximal inhibitory concentration: 300 nM
The estimate for compound 4 lay 2.0-fold (0.30 log units) above the measured number; low and high end bracket the measured number.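

On the core of compound 3, the change from 4-chlorophenyl to 4-nitrophenyl gives a 3.0-fold higher number from compound 3 to compound 4 (0.48 log units; beyond the scatter) in this assay, the same direction as on the core of compound 1. Set side by side, the two steps cannot be told apart in size: the same change on two cores in this assay, a 6.2-fold higher number (0.79 log units; beyond the scatter) from compound 1 to compound 2 and a 3.0-fold higher number (0.48 log units; beyond the scatter) from compound 3 to compound 4, 2.1-fold (0.32 log units) apart, within the scatter of two such steps. Among the compounds shown here, this shows that the change carries over between these two cores in direction and, as far as the scatter allows, in size, but it rests on only two steps and one pair of groups, so it does not show that the step is identical on both cores, that it would hold on a further core, or why it occurs.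

The compounds shown leave open whether an amine or a carboxylic acid in place of chloro would follow the same course on both cores. They also leave open whether the step would persist with a longer chain in place of the one carrying the nitrile.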